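Adding a Hydroxy Group to Compound 2

The compounds below may be only part of what the source reports. "The series", "measured", "known", "first", "only" and "open" are said of these compounds alone.

In a functional assay on SK-OV-3 cells (Homo sapiens) for antiproliferative activity, read by MTT assay, with a stated time of 24 h (on this read-out lower numbers stand for stronger inhibition and higher numbers for weaker inhibition), compound 1 `COc1ccc(C(=O)/C=C/c2ccc([N+](=O)[O-])cc2)c2c1C=CC(C)(C)O2` gives 3420 nM as a measured number. In this assay compound 2 `COc1ccc(C(=O)/C=C/c2cccc(Cl)c2)c2c1C=CC(C)(C)O2` gives only a limit, > 10000 nM and no number. It therefore stands at the limit of > 10000 nM in this assay, at which 1 of the 2 values shown sits, and not at a measured value. Within the data shown here, the one measured step is an at least 2.9-fold higher number from compound 1 to compound 2 (0.46 log units; beyond the scatter) and lies beyond the scatter, but it involves no hydroxy group and so bears on the next change only loosely. Compound 3 `COc1ccc(C(=O)/C=C/c2cc(Cl)ccc2O)c2c1C=CC(C)(C)O2` keeps the chloro group, and 3-chlorophenyl becomes 5-chloro-2-hydroxyphenyl, with hydroxy in place of hydrogen on an aromatic carbon as the counted change. Compound 1 reaches 3420 nM on the same core, so a move toward stronger inhibition is expected, though not a large one. The expected change is an at least 1.6-fold lower number from compound 2 to compound 3 (0.22 log units; that floor lies within the scatter) and it starts from a limit. In this assay compound 3 is estimated at 6000 nM with 2000 nM to 15000 nM as its likely range.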

Compound 3, half-maximal inhibitory concentration: 6270 nM
Beside the measured number, compound 3's estimate is 1.0-fold (0.02 log units) below it; measured number inside the range.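

With the hydroxy group on the aromatic carbon para to the chloro group, compound 3 gives a measured number in this assay, while compound 2 gives only a limit: the limit of > 10000 nM in this assay, at which 1 of the 3 values shown sits. From the compounds shown here alone, the change reads as an at least 1.5-fold lower number from compound 2 to compound 3 (0.20 log units; that floor lies within the scatter), so its true size stays unknown, and this floor alone does not separate the two compounds. Set against the other measured compound, the step is a 1.8-fold higher number from compound 1 to compound 3 (0.26 log units; within the scatter), which leaves 5-chloro-2-hydroxyphenyl and 4-nitrophenyl on the shared core within the scatter of each other.

Going by these compounds, whether a methoxy group or an amine on that same aromatic carbon would give a number like that of compound 3 remains open. Also open, on these data alone, is what a hydroxy group would do on the 4-nitrophenyl group of compound 1.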